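From a sulfanyl chain to diisopropylamino

The source may hold more compounds than are shown below. What is called first, only, known or untested is meant among the compounds shown, and "the series" means these compounds.

Compound 1 `OC[C@H]1O[C@@H](n2cnc3c(COc4ccccc4)ncnc32)[C@H](O)[C@@H]1O` gives > 100000 nM
Compound 2 `OCCSCc1ncnc2c1ncn2[C@@H]1O[C@H](CO)[C@@H](O)[C@H]1O` gives > 100000 nM

In a functional assay on Huh-7 cells (Homo sapiens) for cytotoxicity, read by MTT assay, with a stated time of 3 days (a higher number here means that more compound is tolerated, a lower number that less compound is tolerated), compound 2 stands at > 100000 nM as a limit, not a number. Compound 1 stands at > 100000 nM as a limit too. Compound 3 `CC(C)N(Cc1ncnc2c1ncn2[C@@H]1O[C@H](CO)[C@@H](O)[C@H]1O)C(C)C` differs from compound 2 by diisopropylamino in place of (2-hydroxyethyl)sulfanyl on a saturated chain carbon bound to an aromatic carbon in one change, diisopropylamino in place of (2-hydroxyethyl)sulfanyl. Among the compounds with values here, the one measured step that bears on it is a step that the two limits leave unreadable from compound 1 to compound 2 with both compounds at the limit of > 100000 nM in this assay, at which 2 of the 2 values shown sit, and so it offers no size to carry over. No step beyond the scatter is therefore expected, and no direction can be given. The expected step is a number no higher from compound 2 to compound 3 (the limit leaves the size open) in this assay on this reading. Compound 3 is estimated at 100000 nM with an expected range of 40000 nM to 100000 nM in this account.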

Compound 3, half-maximal cytotoxic concentration: 18000 nM
Compound 3: middle estimate off by 5.6-fold (0.74 log units), on the high side, and the stated range ends above it.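

In this assay the substituent on a saturated chain carbon bound to an aromatic carbon now gives a readable change: an at least 5.5-fold lower number from compound 2 to compound 3 (0.74 log units; beyond the scatter) comes with diisopropylamino in place of (2-hydroxyethyl)sulfanyl, and an at least 5.5-fold lower number from compound 1 to compound 3 (0.74 log units; beyond the scatter) comes with diisopropylamino in place of phenoxy. The earlier step between compound 1 and compound 2 cannot be read, as both compounds rest on the same limit: the limit of > 100000 nM in this assay, at which 2 of the 3 values shown sit. The compounds shown leave open whether a smaller amine such as dimethylamino, or a ring amine such as piperidine, would give a step of like size at this place.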